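Butylamino for benzyloxy on the shared core

A few compounds are considered here, and "the series" means these few. Any claim that something is new, unique, unknown or untested is made for them only; others in the source may bear on it.

The series shares one core, varied at a single aromatic carbon. Compound 1 `CN(C)c1nc(N)nc2c1ncn2/C=C1/CC1(CO)CO` carries dimethylamino there, compound 2 `Nc1nc(OCc2ccccc2)c2ncn(/C=C3/CC3(CO)CO)c2n1` benzyloxy, and compound 3 `Nc1nc(SC2CCCC2)c2ncn(/C=C3/CC3(CO)CO)c2n1` cyclopentylsulfanyl. In an ADME assay on BCBL1 cells (Homo sapiens) for cytotoxicity, with a stated time of 7 days (a higher number here means that more compound is tolerated, a lower number that less compound is tolerated), compound 1 gives > 20000 nM, which is a limit of the assay and not a number. Compound 2 gives > 20000 nM, likewise a limit. Compound 3 gives > 20000 nM, again a limit. Compound 2 therefore stands where every measured member stands, at the limit of > 20000 nM in this assay, at which 3 of the 3 values shown sit. The steps measured so far are a step that the two limits leave unreadable from compound 1 to compound 2, a step that the two limits leave unreadable from compound 1 to compound 3 and a step that the two limits leave unreadable from compound 2 to compound 3; none of them can be sized, so no direction of change in this assay has been read for any swap at this carbon.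

Compound 4 `CCCCNc1nc(N)nc2c1ncn2/C=C1/CC1(CO)CO` is the next member, differing from compound 2 as follows: butylamino in place of benzyloxy on an aromatic carbon. All three measured steps bear on it in the sense that each replaces one group at this carbon, and all three are unreadable at the limit. No step beyond the scatter is therefore expected in this assay. For compound 4 the expected value is 30000 nM, estimated to lie between 15000 nM and 100000 nM. The step this estimate implies, a step that the limit leaves unreadable from compound 2 to compound 4, is expected to be none beyond the scatter, most likely reported again only as a limit.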

Compound 4, half-maximal cytotoxic concentration: > 20000 nM
Compound 4 gave a limit, no number (the forecaster's own chance of this, stated with the estimate: 85%); the middle value does not contradict the limit.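

In this assay compound 4 gives > 20000 nM, a limit of the assay and not a number. Its steps to compound 1, compound 2 and compound 3 cannot be read: the limit of > 20000 nM in this assay, at which 4 of the 4 values shown sit. The compounds shown leave open whether any group at this aromatic carbon changes the tolerated concentration, and by how much.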